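This account rests on a few compounds, and the source may have more. Where it says the series, first, only, none or still open, it means among the compounds named here.

Measured compounds:
- compound 1, `CN(C(=O)NC(=O)c1ccc(Cl)cc1Cl)c1nc(C(F)(F)F)c(C(=O)N/N=C/c2cccc(C(F)(F)F)c2)s1`: 9.6 ug/mL
- compound 2, `CN(C(=O)NC(=O)c1cccc(C(F)(F)F)c1)c1nc(C(F)(F)F)c(C(=O)N/N=C/c2ccc(C(F)(F)F)cc2)s1`: 7.35 ug/mL
- compound 3, `CN(C(=O)NC(=O)c1ccc(C(F)(F)F)cc1)c1nc(C(F)(F)F)c(C(=O)N/N=C/c2cccc(C(F)(F)F)c2)s1`: 6.2 ug/mL

In a functional assay on HeLa cells (Homo sapiens) for inhibition, read by MTT assay, with a stated time of 72 h (a higher number here means a weaker inhibitor, a lower number a stronger inhibitor), compound 3 gives the lowest of the three numbers, yet its gaps to compound 2 and to compound 1 both lie within the scatter, so no ordering among the three can be read. Among the compounds with values here, the one single-place step recorded, a 1.5-fold lower number from compound 1 to compound 3 (0.19 log units; within the scatter), is itself within the scatter.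

Compound 4, `CN(C(=O)NC(=O)c1cccc(C(F)(F)F)c1)c1nc(C(F)(F)F)c(C(=O)N/N=C/c2cccc(C(F)(F)F)c2)s1`, differs from compound 3 by 3-(trifluoromethyl)phenyl in place of 4-(trifluoromethyl)phenyl on a carbonyl carbon; the two have the same atoms, joined differently. Within the data shown here, no measured step covers this exact change. Compound 2 carries the same 3-(trifluoromethyl)phenyl on its carbonyl carbon, and its value sits within the scatter of compound 3, which is the only bearing the data give. Compound 4 is therefore expected to show no step beyond the scatter, a 1.1-fold higher number from compound 3 to compound 4 (0.05 log units; within the scatter), with an estimated value of 7 ug/mL in this assay, ranging from 3.5 ug/mL to 14 ug/mL.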

Compound 4, half-maximal inhibitory concentration: 4.81 ug/mL
For compound 4 the middle estimate is 1.5-fold (0.16 log units) above the measured one, within the range that was stated.
By their numbers in this assay, from the lowest: compounds 4, 3, 2 and 1 (each within the scatter of the next).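

In this assay, 3-(trifluoromethyl)phenyl in place of 4-(trifluoromethyl)phenyl on a carbonyl carbon gives a 1.3-fold lower number from compound 3 to compound 4 (0.11 log units; within the scatter) and the same exchange on a carbon with a double bond to nitrogen gives a 1.5-fold lower number from compound 2 to compound 4 (0.18 log units; within the scatter) so neither place separates the two groups. On the carbonyl carbon, 3-(trifluoromethyl)phenyl in place of 2,4-dichlorophenyl gives a 2.0-fold lower number from compound 1 to compound 4 (0.30 log units; within the scatter) and this wider exchange also stays within the scatter.

Going by these compounds, whether a carboxylic acid or an amine in place of the trifluoromethyl group would give a step beyond the scatter remains open. No supporting measurement bears on these steps.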